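The compounds below may be only part of what the source reports. "The series", "measured", "known", "first", "only" and "open" are said of these compounds alone.

Measured compounds in a functional assay on MDA-MB-231 cells (Homo sapiens) for cytotoxicity, read by MTT assay, with a stated time of 48 h; on this read-out higher numbers stand for weaker inhibition and lower numbers for stronger inhibition:
- Compound 1, `Cn1cccc1C(=O)/C=C/c1ccc2c(c1)B(O)OC2` — for compound 1 the result > 100000 nM is a limit of the assay, not a number.
- Compound 2, `Nc1ccc(C(=O)/C=C/c2ccc3c(c2)B(O)OC3)cc1` — compound 2 gives 25800 nM.
- Compound 3, `O=C(/C=C/c1ccc2c(c1)B(O)OC2)c1cccc(F)c1` — compound 3 gives 3000 nM.

Compound 3 has the lowest of the two numbers; its nearest neighbour is compound 2, and the step of an 8.6-fold lower number from compound 2 to compound 3 (0.93 log units; beyond the scatter) sets it apart. The other steps point the same way: an at least 3.8-fold lower number from compound 1 to compound 2 (0.58 log units; beyond the scatter) and an at least 33-fold lower number from compound 1 to compound 3 (1.52 log units; beyond the scatter), the latter resting on the limit described in the limit of > 100000 nM in this assay, at which 1 of the 3 values shown sits.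

Compound 4, `O=C(/C=C/c1ccc2c(c1)B(O)OC2)c1ccccc1O`, carries the same core as compound 3. The change is 2-hydroxyphenyl in place of 3-fluorophenyl on a carbonyl carbon. All three measured steps alter the group on this same carbonyl carbon, so they are the ones that bear on it. Compound 2, whose group also carries a hydrogen-bond donor, gave a higher number than compound 3, and the step of an 8.6-fold lower number from compound 2 to compound 3 (0.93 log units; beyond the scatter) was modest. A modest rise from compound 3 to compound 4 is therefore expected, with the estimated step of a 2.3-fold higher number from compound 3 to compound 4 (0.37 log units; beyond the scatter). Compound 4 is expected to give about 7000 nM in this assay, within a range from 2000 nM to 25000 nM.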

Compound 4, half-maximal inhibitory concentration: 16900 nM
Estimate against measurement, compound 4: 2.4-fold (0.38 log units) below; measured number inside the range.
By their numbers in this assay, from the lowest: compound 3; then compounds 4 and 2 (each within the scatter of the next). At a limit, above all of these: compound 1.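

In this assay, the change from 3-fluorophenyl to 2-hydroxyphenyl shows that two substituted phenyl groups with the same heavy-atom count are not interchangeable on this carbonyl carbon: a 5.6-fold higher number from compound 3 to compound 4 (0.75 log units; beyond the scatter). Against compound 2, whose 4-aminophenyl group also carries a hydrogen-bond donor, the result is a 1.5-fold lower number from compound 2 to compound 4 (0.18 log units; within the scatter), so these two groups cannot be told apart here, and both compounds give higher numbers than compound 3. Compound 1 goes against any simple rule about donors, since its 1-methyl-1H-pyrrol-2-yl group has none, and an at least 5.9-fold lower number from compound 1 to compound 4 (0.77 log units; beyond the scatter) rests on a result that is a limit of the assay for compound 1, not a number: the limit of > 100000 nM in this assay, at which 1 of the 4 values shown sits.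

Two things change at once from compound 3 to compound 4, the substituent and where it sits on the phenyl ring, and the compounds shown do not separate them. They also leave open how this position would respond to a methoxy group, which keeps the oxygen of the hydroxyl but not its hydrogen, or to a carboxylic acid on the same phenyl ring.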